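Hydroxy-bearing core: nitro replaces methoxy on the phenyl ring

A few compounds are considered here, and "the series" means these few. Any claim that something is new, unique, unknown or untested is made for them only; others in the source may bear on it.

Compound 1, `CCCCOC1(c2ccc(Br)cc2)SC=C(C)n2c1noc2=O`: 82000 nM
Compound 2, `COc1ccc(C2(O)SC=C(C)n3c2noc3=O)cc1`: > 100000 nM

Both figures come from a functional assay on A2780 cells (Homo sapiens) for antiproliferative activity, read by MTT assay, with a stated time of 3 days; on this read-out lower numbers stand for stronger inhibition and higher numbers for weaker inhibition. Compound 1 gives 82000 nM there. For compound 2 the result is a limit of the assay rather than a number, > 100000 nM, the point (the limit of > 100000 nM in this assay, at which 1 of the 2 values shown sits). Compound 3, `CC1=CSC(O)(c2ccc([N+](=O)[O-])cc2)c2noc(=O)n21`, differs from compound 2 by nitro in place of methoxy on an aromatic carbon. For the measured compounds named here, no measured pair isolates this change, so no step beyond the scatter is expected in this assay in either direction. Compound 3 is accordingly estimated at 100000 nM (range 40000 nM to 300000 nM), an expected step of a number no higher from compound 2 to compound 3 (the limit leaves the size open).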

Compound 3, half-maximal inhibitory concentration: > 100000 nM
Compound 3 ended at the assay's limit; the forecaster's own chance of this, stated with the estimate: 60%; the middle value sits exactly at the limit.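

For the compounds shown here, compound 2 and compound 3 both end at a limit of this assay, so no step between them can be read: the limit of > 100000 nM in this assay, at which 2 of the 3 values shown sit.

On these data alone, whether nitro in place of methoxy on an aromatic carbon changes the result in this assay stays open.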